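Amide Swap on a Bis(chlorophenyl) Series

A few compounds are considered here, and "the series" means these few. Any claim that something is new, unique, unknown or untested is made for them only; others in the source may bear on it.

Measured in a functional assay on A549 cells (Homo sapiens) for inhibition, read by sulforhodamine B assay, with a stated time of 72 h; a higher number here means a weaker inhibitor, a lower number a stronger inhibitor:
- compound 1 `Nc1sc(-c2ccc(Cl)cc2)c(-c2ccc(Cl)cc2)c1C(=O)NC1CCC(O)CC1`: 250 nM
- compound 2 `Nc1sc(-c2ccc(Cl)cc2)c(-c2ccc(Cl)cc2)c1C(=O)N1CCOCC1`: 1870 nM
- compound 3 `Nc1sc(-c2ccc(Cl)cc2)c(-c2ccc(Cl)cc2)c1C(=O)N1CCCC1`: 890 nM

Compound 3 sits in the middle of this short series. The step of a 2.1-fold lower number from compound 2 to compound 3 (0.32 log units; beyond the scatter) separates it from the highest number, and the step of a 3.6-fold higher number from compound 1 to compound 3 (0.55 log units; beyond the scatter) separates the lowest number from it.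

Compound 4 `COc1ccc(CNC(=O)c2c(N)sc(-c3ccc(Cl)cc3)c2-c2ccc(Cl)cc2)cc1` replaces that pyrrolidin-1-yl with (4-methoxybenzyl)amino on a carbonyl carbon ((4-methoxybenzyl)amino in place of pyrrolidin-1-yl on a carbonyl carbon). Like compound 1, it keeps the amide hydrogen, so the step of a 3.6-fold higher number from compound 1 to compound 3 (0.55 log units; beyond the scatter) is the closest guide, read in reverse. The step of a 7.5-fold higher number from compound 1 to compound 2 (0.87 log units; beyond the scatter) also shows that this position responds to substitution. However, the group in compound 4 differs from the (4-hydroxycyclohexyl)amino of compound 1, and no measured compound carries a benzyl group, so only part of that gain is assumed.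

The expected change is a 2.0-fold lower number from compound 3 to compound 4 (0.30 log units; within the scatter), a modest move towards stronger inhibition. For compound 4 the estimated value is 450 nM, with an expected range of 150 nM to 1400 nM.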

Compound 4, half-maximal inhibitory concentration: 18200 nM
Compound 4: the middle estimate sits 40-fold (1.61 log units) below what was measured, and the stated range ends below it.
By their numbers in this assay, from the lowest: compound 1; then compound 3; then compound 2; then compound 4.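

The amide hydrogen alone does not set the level at this carbonyl carbon in this assay, since the two amides that keep it lie at opposite ends of the series (a 73-fold higher number from compound 1 to compound 4 (1.86 log units; beyond the scatter)). The pyrrolidin-1-yl and morpholin-4-yl amides, which lack that hydrogen, both give lower numbers than the (4-methoxybenzyl)amino amide (a 20-fold higher number from compound 3 to compound 4 (1.31 log units; beyond the scatter); a 9.7-fold higher number from compound 2 to compound 4 (0.99 log units; beyond the scatter)), so this position is far less tolerant of the last group than the first three compounds suggested. Nothing available accounts for this loss.

The compounds shown leave open whether the loss goes with the methoxy group or with the benzyl group itself, which plain benzylamino or a 4-hydroxybenzylamino group would help to separate. They also leave open how much of the strength of compound 1 rests on its hydroxyl, which plain cyclohexylamino would address.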